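Halogen pattern on the sulfonamide aryl ring and binding

The compounds below may be only part of what the source reports. "The series", "measured", "known", "first", "only" and "open" are said of these compounds alone.

Measured so far:
- compound 1 `COc1ccc(S(=O)(=O)Nc2cccc(I)c2)cc1N1CCNCC1`: 0.501 nM
- compound 2 `COc1ccc(S(=O)(=O)Nc2c(F)cc(Br)cc2F)cc1N1CCNCC1`: 158 nM
- compound 3 `COc1ccc(S(=O)(=O)Nc2cc(Br)cc(Br)c2Br)cc1N1CCNCC1`: 2.51 nM

All three share one core and were tested in an assay on isolated protein for binding affinity to 5-hydroxytryptamine receptor 6 (Homo sapiens); a lower number here means a stronger inhibitor, a higher number a weaker inhibitor. Compound 2 stands at the highest number of the three, making it the weakest binder of this small set: compound 3 is its nearest neighbour, with a 63-fold lower number from compound 2 to compound 3 (1.80 log units; beyond the scatter), while compound 1 is the furthest, as the large step of a 320-fold higher number from compound 1 to compound 2 (2.50 log units; beyond the scatter) shows. The same aryl group on the sulfonamide nitrogen thus moves the number across a wide span.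

Compound 4 `COc1ccc(S(=O)(=O)Nc2cc(Br)cc(F)c2Cl)cc1N1CCNCC1` differs from compound 2 in that single place: 5-bromo-2-chloro-3-fluorophenyl in place of 4-bromo-2,6-difluorophenyl on a sulfonamide nitrogen. Among the compounds with values here, the step that bears most directly on it is the one from compound 2 to compound 3, where the 4-bromo-2,6-difluorophenyl was likewise exchanged for a ring carrying three halogens, including bromine, and the number fell sharply, a 63-fold lower number from compound 2 to compound 3 (1.80 log units; beyond the scatter). Within the data shown here, the change to compound 4 again removes the 4-bromo-2,6-difluorophenyl in favour of a three-halogen ring, so a large drop is expected, roughly a 40-fold lower number from compound 2 to compound 4 (1.60 log units; beyond the scatter), though compound 4 keeps one fluorine and carries a chlorine, which no measured compound tests.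

Compound 4 is therefore estimated at about 4 nM, with a likely range from 1 nM to 20 nM.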

Compound 4, inhibition constant: 3.16 nM
For compound 4 the middle estimate is 1.3-fold (0.10 log units) above the measured one, and the stated range covers the measured number.
By their numbers in this assay, from the lowest: compound 1; then compounds 3 and 4 (each within the scatter of the next); then compound 2.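

Compound 4 shows that the sharp fall seen with compound 3 is not tied to the 2,3,5-tribromophenyl group: the 5-bromo-2-chloro-3-fluorophenyl group gives a 50-fold lower number from compound 2 to compound 4 (1.70 log units; beyond the scatter) in this assay, a large step of about the same order. Replacing the bromines of the 2,3,5-tribromophenyl group with a chlorine and a fluorine, while the bromine named at position 5 stays, brings only a 1.3-fold higher number from compound 3 to compound 4 (0.10 log units; within the scatter), so this ring tolerates a change of halogen at those two places, and a fluorine on the ring does not by itself go with a number as high as that of compound 2. Neither of these rings matches the single iodine of the 3-iodophenyl group, as a 6.3-fold higher number from compound 1 to compound 4 (0.80 log units; beyond the scatter) makes clear.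

Every ring shown here carries only halogens, so it remains open how a nitrile, an amine or a carboxylic acid on this ring would compare, and how a plain phenyl with no substituent would sit against the 3-iodophenyl group. Within the data shown here, nothing available here explains why the halogen pattern moves the number so far.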